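Swapping Fluoro for Nitro on an Aromatic Ring

The compounds below may be only part of what the source reports. "The series", "measured", "known", "first", "only" and "open" are said of these compounds alone.

compound 1 `Cc1ccccc1N1CCN(C(=S)SCc2ccc3nc(N)nc(N)c3c2)CC1` gives 4230 nM
compound 2 `Nc1nc(N)c2cc(CSC(=S)N3CCN(c4ccc(F)cc4)CC3)ccc2n1` gives 1920 nM

Within the data shown here, in a functional assay on MCF7 cells (Homo sapiens) for antiproliferative activity, read by MTT assay, with a stated time of 72 h (a lower number here means a stronger inhibitor, a higher number a weaker inhibitor), compound 2 gives 1920 nM as the lowest of the two numbers so far. Compound 3 `Nc1nc(N)c2cc(CSC(=S)N3CCN(c4ccc([N+](=O)[O-])cc4)CC3)ccc2n1` has nitro in place of fluoro on an aromatic carbon, para to a large group (nitro in place of fluoro on an aromatic carbon). Among the measured compounds shown here, one measured step bears on this change: a 2.2-fold lower number from compound 1 to compound 2 (0.34 log units; beyond the scatter) with 4-fluorophenyl in place of 2-methylphenyl. That step was modest, though beyond the scatter. For the measured compounds named here, it shows that a swap on this aromatic group can move the number, but no measured compound carries a nitro, so the direction stays open. No step beyond the scatter is therefore expected in this assay, and the estimated outcome is a 1.0-fold higher number from compound 2 to compound 3 (0.02 log units; within the scatter) for now. For compound 3 the estimate is 2000 nM with an expected range of 700 nM to 5500 nM on this assay.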

Compound 3, half-maximal inhibitory concentration: 1470 nM
Beside the measured number, compound 3's estimate is 1.4-fold (0.13 log units) above it, and the stated range covers the measured number.
By their numbers in this assay, from the lowest: compounds 3 and 2 (each within the scatter of the next); then compound 1.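

In this assay, nitro in place of fluoro on an aromatic carbon, para to a large group, gives a 1.3-fold lower number from compound 2 to compound 3 (0.12 log units; within the scatter), so this assay does not separate the two groups, although they differ in heavy atoms and hydrogen-bond acceptors. The change from the 2-methylphenyl of compound 1 to 4-nitrophenyl gives a 2.9-fold lower number from compound 1 to compound 3 (0.46 log units; beyond the scatter), a second modest step beyond the scatter, and it matches the earlier step to 4-fluorophenyl in direction. Nothing measured here explains these numbers.

On these data alone, whether an amine or a carboxylic acid on this aromatic carbon would give a number clearly apart from these remains open. Also open, as far as these compounds go, is how much of the difference from compound 1 comes from the group itself and how much from where it sits on the ring.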